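Moving the Methyl Group from 2-Methylphenyl to 4-Methylphenyl

The compounds below may be only part of what the source reports. "The series", "measured", "known", "first", "only" and "open" are said of these compounds alone.

In a functional assay, with a stated time of 6 min (on this read-out lower numbers stand for stronger inhibition and higher numbers for weaker inhibition), compound 1 (`S=c1oc(-c2ccc3c(c2)OCCO3)nn1CNc1ccccc1Cl`) gives 7230 nM. Compound 2 (`Cc1ccccc1NCn1nc(-c2ccc3c(c2)OCCO3)oc1=S`) gives 3450 nM, the lower of the two numbers. Compound 3 (`Cc1ccc(NCn2nc(-c3ccc4c(c3)OCCO4)oc2=S)cc1`) differs from compound 2 by one change, 4-methylphenyl in place of 2-methylphenyl on an amine nitrogen. Among the compounds with values here, the only measured step that bears on this, a 2.1-fold lower number from compound 1 to compound 2 (0.32 log units; beyond the scatter), is modest and exchanges one group for another, so it offers only a rough guide to size and none to direction. No shift beyond the scatter is therefore expected in this assay, and the estimated change is a 1.3-fold higher number from compound 2 to compound 3 (0.12 log units; within the scatter). For compound 3 the expected value is 4500 nM, with an estimated range of 1500 nM to 12000 nM.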

Compound 3, half-maximal inhibitory concentration: 5700 nM
Compound 3: the middle estimate sits 1.3-fold (0.10 log units) below what was measured; the measured number falls inside the stated range.
By their numbers in this assay, from the lowest: compounds 2, 3 and 1 (each within the scatter of the next, the first and the last beyond it).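

In this assay, 4-methylphenyl in place of 2-methylphenyl on the amine nitrogen gives a 1.7-fold higher number from compound 2 to compound 3 (0.22 log units; within the scatter), so relocating the methyl group does not separate these two compounds. Replacing 2-chlorophenyl with 4-methylphenyl gives a 1.3-fold lower number from compound 1 to compound 3 (0.10 log units; within the scatter), so compound 3 cannot be ranked against compound 1 or compound 2, although those two stand apart. Nothing available explains these numbers. The compounds shown leave open whether a carboxylic acid or an amine in place of the methyl group would shift the number beyond the scatter.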